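Swapping a Bromoalkyl Amide for Nitro on a Benzamide

The source may report more compounds than this note shows. Statements on the series, on what has been measured and on what is new or still open speak of the compounds shown alone.

In a toxicity assay on Huh-7.5 cells (Homo sapiens) for inhibition, read by MTT assay, with a stated time of 96 h (a lower number here means that less compound is tolerated, a higher number that more compound is tolerated), compound 3 `CC(C)Oc1ccc(C(=O)Nc2ccc(CN3CCN(C)CC3)c(C(F)(F)F)c2)cc1NC(=O)C(C)Br` gives 8700 nM, the lowest of the three numbers reported. Compound 1 `CN1CCN(Cc2ccc(NC(=O)c3ccc(OCCCCl)c([N+](=O)[O-])c3)cc2C#N)CC1` gives 15500 nM, which lies within the scatter of the number for compound 3, whereas compound 2 `CCC(=O)Nc1cc(C(=O)Nc2ccc(OC)cc2)ccc1OC` gives 109000 nM, a gap beyond the scatter. Compound 4 `CC(C)Oc1ccc(C(=O)Nc2ccc(CN3CCN(C)CC3)c(C(F)(F)F)c2)cc1[N+](=O)[O-]` has not yet been measured in this assay. It differs from compound 3 in one place: nitro in place of ((1-bromoethyl)carbonyl)amino on an aromatic carbon. Within the data shown here, no step between two measured compounds covers this exact change, so the expectation rests only on the spread of the measured numbers. Compound 4 is expected to be somewhat more tolerated than compound 3, with an expected step of a 2.3-fold higher number from compound 3 to compound 4 (0.36 log units; beyond the scatter) that may not clearly exceed the scatter. The estimate for compound 4 is 20000 nM, with a range from 7000 nM to 60000 nM.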

Compound 4, half-maximal cytotoxic concentration: 3500 nM
Compound 4: the middle estimate sits 5.7-fold (0.76 log units) above what was measured, and the stated range ends above it.
By their numbers in this assay, from the lowest: compound 4; then compounds 3 and 1 (each within the scatter of the next); then compound 2.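

At the aromatic carbon ortho to an isopropoxy group, nitro in place of ((1-bromoethyl)carbonyl)amino gives a 2.5-fold lower number from compound 3 to compound 4 (0.40 log units; beyond the scatter) in this assay, a modest change. Among these compounds, this is the first single-place comparison in the set, and it shows that the bromoalkyl amide is not required at this position for a low number, since the smaller nitro group gives a lower one. No available evidence accounts for this step.

The compounds shown do not separate the contribution of the bromine from that of the amide. As far as these compounds go, how an amine or a carboxylic acid on this carbon would compare remains open.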